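Swapping the aryl amine for methylpiperazine on the dithiocarbamate

The source may report more compounds than this note shows. Statements on the series, on what has been measured and on what is new or still open speak of the compounds shown alone.

Measured compounds:
Compound 1, `Nc1ccccc1NC(=O)c1ccc(CSC(=S)N2CCN(c3ccccc3)CC2)cc1`: 88.6%
Compound 2, `CN(C(=S)SCc1ccc(C(=O)Nc2ccccc2N)cc1)c1cccnc1`: 87.7%
Compound 3, `Cc1ccc(N2CCN(C(=S)SCc3ccc(C(=O)Nc4ccccc4N)cc3)CC2)cc1`: 26.4%

All three were tested in a functional assay on A-375 cells (Homo sapiens) for antiproliferative activity, read by CCK-8 assay, with a stated time of 72 h, tested at 8 uM; a lower number here means a weaker effect, a higher number a stronger effect of the compound at the concentration tested. Compound 2 stands second highest of the three numbers in this assay; its nearest neighbour is compound 1, and the two values lie within the scatter of each other, so no order between them can be claimed. Compound 3 lies far lower, beyond the scatter.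

Compound 4, `CN1CCN(C(=S)SCc2ccc(C(=O)Nc3ccccc3N)cc2)CC1`, is not yet measured. It differs from compound 2 in one place: 4-methylpiperazin-1-yl in place of methyl(pyridin-3-yl)amino on a thiocarbonyl carbon.

For the measured compounds named here, only one step between measured compounds exists here, a number 62.2 percentage points lower from compound 1 to compound 3 (beyond the scatter), and it concerns a methyl in place of hydrogen on an aromatic carbon, not the group on the thiocarbonyl carbon. It shows that a small change elsewhere in the shared core can move the number a great deal, but it gives no direct guide to the change from compound 2 to compound 4. Compound 1 and compound 2 carry different groups on that carbon and give values within the scatter of each other, which weakly suggests that this position tolerates variation. Going by the values given here, with no closer precedent, a downward step of moderate size, a number 27.7 percentage points lower from compound 2 to compound 4 (beyond the scatter), is expected, with wide uncertainty. Compound 4 is therefore estimated at 60%, in a range from 20% to 92%.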

Compound 4, a percentage reported as inhibition, at one concentration (the size of the read-out at that concentration, not a potency): 91.6%
Estimate against measurement, compound 4: 31.6 percentage points below, and the stated range covers the measured number.
By their numbers in this assay, from the lowest: compound 3; then compounds 2, 1 and 4 (each within the scatter of the next).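

In this assay the change on the thiocarbonyl carbon gives a number 3.9 percentage points higher from compound 2 to compound 4 (within the scatter), so the aromatic ring of methyl(pyridin-3-yl)amino is not required there: a non-aromatic ring, 4-methylpiperazin-1-yl, serves as well at the concentration tested. For the compounds shown here, the ring nitrogen of the piperazine also accepts a small methyl in place of phenyl, with a number 3 percentage points higher from compound 1 to compound 4 (within the scatter), yet a number 65.2 percentage points higher from compound 3 to compound 4 (beyond the scatter) is a large step, which leaves compound 3, with its 4-methylphenyl group, as the one compound that goes against this tolerance. Nothing shown explains why that single compound stands apart.

As far as these compounds go, it stays open whether a longer chain such as ethyl or 2-hydroxyethyl on that ring nitrogen, or a morpholine ring on the thiocarbonyl carbon, would keep the number as high. Since this assay reports the size of the effect at one concentration only, compound 1, compound 2 and compound 4 could still show a stronger or weaker effect than one another at other concentrations, which a full concentration series would be needed to show.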